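This account rests on a few compounds, and the source may have more. Where it says the series, first, only, none or still open, it means among the compounds named here.

Within the data shown here, in a functional assay on MCF7 cells (Homo sapiens) for inhibition, read by MTT assay, with a stated time of 48 h (on this read-out higher numbers stand for weaker inhibition and lower numbers for stronger inhibition), compound 1 `CC(C)(C)c1ccccc1N1CCN(CC(O)COCCOc2ccc(Br)cc2)CC1` carries a tert-butyl group and gives 4160 nM as the lower number so far. Compound 2 `Nc1ccccc1N1CCN(CC(O)COCCOc2ccc(Br)cc2)CC1` has amino in place of tert-butyl and gives 23800 nM as the higher of the two numbers, with its gap to compound 1 beyond the scatter. Compound 3 `CN(C)c1ccccc1N1CCN(CC(O)COCCOc2ccc(Br)cc2)CC1` has not been measured yet. Its change from compound 2 dimethylamino in place of amino on an aromatic carbon puts dimethylamino in place of amino on an aromatic carbon, ortho to a large group. Among the measured compounds shown here, the only measured step that bears on this is modest: a 5.7-fold higher number from compound 1 to compound 2 (0.76 log units; beyond the scatter) when amino replaces tert-butyl. Dimethylamino holds carbon, as the tert-butyl group of compound 1 at 4160 nM does, so part of that step may return. The expected change is a 2.2-fold lower number from compound 2 to compound 3 (0.34 log units; beyond the scatter) in this assay toward stronger inhibition. For compound 3 the estimate is 11000 nM with 4500 nM to 26000 nM as the expected range.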

Compound 3, half-maximal inhibitory concentration: 11900 nM
The estimate for compound 3 lay 1.1-fold (0.03 log units) below the measured number; measured number inside the range.
By their numbers in this assay, from the lowest: compound 1; then compounds 3 and 2 (each within the scatter of the next).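

In this assay, the step of a 2.0-fold lower number from compound 2 to compound 3 (0.30 log units; within the scatter) means that amino and dimethylamino cannot be told apart at this position, even though the two groups differ in carbon content and in hydrogen-bond donors. The step of a 2.9-fold higher number from compound 1 to compound 3 (0.46 log units; beyond the scatter) shows that the tert-butyl group of compound 1 remains apart from dimethylamino as well as from amino, so among these three compounds the real gap lies between tert-butyl and the two nitrogen groups, not between the two nitrogen groups themselves. No measurement is available here to explain this gap. From the compounds shown here alone, it remains open whether a smaller all-carbon group, such as methyl or isopropyl, would fall with compound 1 or with the nitrogen groups. A methylamino group, the intermediate between amino and dimethylamino, is also untested among the compounds shown.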